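This account rests on a few compounds, and the source may have more. Where it says the series, first, only, none or still open, it means among the compounds named here.

Measured so far in an ADME assay on Vero cells (Chlorocebus sabaeus) for cytotoxicity, read by MTT assay; on this read-out higher numbers stand for lower toxicity in this test and lower numbers for higher toxicity in this test:
- compound 1 `COc1ccc(-c2nc3cnccn3c2Nc2cc(OC)c(OC)c(OC)c2)cc1`: 75000 nM
- compound 2 `COc1cc(Nc2c(-c3ccc(F)cc3)nc3cnccn23)cc(OC)c1OC`: 48000 nM

Going by the values given here, compound 2 cannot be told apart from the only other measured compound, as the one measured step shows: a 1.6-fold lower number from compound 1 to compound 2 (0.19 log units; within the scatter). That step put fluoro in place of methoxy on an aromatic carbon of the ring that now leaves.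

Compound 3 `COc1cc(-c2nc3cnccn3c2Nc2cc(OC)c(OC)c(OC)c2)cc(OC)c1O` has 4-hydroxy-3,5-dimethoxyphenyl in place of 4-fluorophenyl on an aromatic carbon. Among the compounds with values here, this swap is larger than the measured one, and no measured compound tests it directly. Since the step in compound 2 stayed so small, a 1.6-fold lower number from compound 1 to compound 2 (0.19 log units; within the scatter), no clear shift in this assay is expected. The expected step is a 1.1-fold higher number from compound 2 to compound 3 (0.06 log units; within the scatter). For compound 3 the estimated value is 55000 nM, within an expected range of 22000 nM to 130000 nM.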

Compound 3, concentration lethal to 50% of the cells: 62000 nM
For compound 3 the middle estimate is 1.1-fold (0.05 log units) below the measured one, within the range that was stated.
By their numbers in this assay, from the lowest: compounds 2, 3 and 1 (each within the scatter of the next).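

In this assay, this aromatic carbon of the five-membered ring accepts the larger 4-hydroxy-3,5-dimethoxyphenyl, with its hydrogen-bond donor, without a step beyond the scatter: the change gives a 1.3-fold higher number from compound 2 to compound 3 (0.11 log units; within the scatter), and against 4-methoxyphenyl it gives a 1.2-fold lower number from compound 1 to compound 3 (0.08 log units; within the scatter). All three aromatic groups shown at this place therefore cannot be told apart on this read-out. No measurement at hand accounts for this.

Going by these compounds, whether an amine or a carboxylic acid on this carbon, in place of the aromatic ring, would give a clear step remains open.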